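The compounds below may be only part of what the source reports. "The series", "measured", "known", "first", "only" and "open" are said of these compounds alone.

Measured so far in an in vitro ADME assay on microsomes from liver (Homo sapiens) for metabolic stability, tested at 5 uM (on this read-out lower numbers stand for a shorter-lived compound and higher numbers for a longer-lived compound), with these results
compound 1 `CCC(C)(C)c1nn(CCC(C)C)c(=O)c(C2=NS(=O)(=O)c3cc(NS(C)(=O)=O)ccc3N2)c1O` gives 0.1 h as a number
compound 2 `CS(=O)(=O)Nc1ccc2c(c1)S(=O)(=O)N=C(c1c(O)c(-c3cccs3)nn(CCC3CC3)c1=O)N2` gives > 1 h as a limit
compound 3 `CS(=O)(=O)Nc1ccc2c(c1)S(=O)(=O)N=C(c1c(O)c(-c3cccs3)nn(CC3CCC3)c1=O)N2` gives > 1 h as a limit

Compound 3 stands at > 1 h as a limit of the assay and not as a number. Among the measured compounds shown here, compound 2 also stands at a limit, so compound 1 holds the only numerical reading of the three.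

The compound still unmeasured is compound 4 `CC(C)Cn1nc(-c2cccs2)c(O)c(C2=NS(=O)(=O)c3cc(NS(C)(=O)=O)ccc3N2)c1=O` which carries isopropyl in place of cyclobutyl on a saturated chain carbon bound to an aromatic nitrogen. Cut one bond further out, the same difference reads cyclobutylmethyl to isobutyl, and isopropyl in place of cyclobutyl on a saturated chain carbon bound to an aromatic nitrogen gives the full count.

For the measured compounds named here, the one measured step at this place is a step that the two limits leave unreadable from compound 2 to compound 3 and no size can be taken from it. The series therefore offers only the limit of > 1 h in this assay, at which 2 of the 3 values shown sit, as its evidence here, and no readable step at this place exists.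

In this assay the estimate is a step that the limit leaves unreadable from compound 3 to compound 4 and a move beyond the scatter in either direction is not expected. Compound 4 is estimated at 1.5 h with an expected range from 0.5 h to 5 h. A limit rather than a number is a likely outcome for compound 4.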

Compound 4, half-life: > 1 h
Compound 4 gave a limit, no number; the forecaster's own chance of this, stated with the estimate: 65%; the middle value is on the limit's open side.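

In this assay compound 4 gives > 1 h, a limit of the assay and not a number. No new step can be read, since compound 2, compound 3 and compound 4 all stand at limits. The compounds shown leave open how far apart the half-lives of these three lie, and whether isopropyl, cyclobutyl and cyclopropylmethyl differ at all at this place.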